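From an Open Chain Back to a Five-Membered Ring

This account rests on a few compounds, and the source may have more. Where it says the series, first, only, none or still open, it means among the compounds named here.

Measured compounds:
Compound 1 `Nc1ncnc2c1ncn2[C@@H]1O[C@H](COS(=O)(=O)NC(=O)[C@@H]2CCCN2)[C@@H](O)[C@H]1O`: 700 nM
Compound 2 `CCC[C@H](N)C(=O)NS(=O)(=O)OC[C@H]1O[C@@H](n2cnc3c(N)ncnc32)[C@H](O)[C@@H]1O`: 4700 nM

In a functional assay on PBMC cells (Homo sapiens) for inhibition (a higher number here means a weaker inhibitor, a lower number a stronger inhibitor), compound 1 gives 700 nM, and compound 2 gives 4700 nM in this assay, the higher of the two numbers. For the measured compounds named here, the single measured step, a 6.7-fold higher number from compound 1 to compound 2 (0.83 log units; beyond the scatter), replaced a five-membered ring with an open chain. Compound 3 `Nc1ncnc2c1ncn2[C@@H]1O[C@H](COS(=O)(=O)NC(=O)[C@@H]2CSCN2)[C@@H](O)[C@H]1O` is not yet measured; it differs from compound 2 by 1,3-thiazolidin-4-yl in place of 1-aminobutyl on a carbonyl carbon. Because the step of a 6.7-fold higher number from compound 1 to compound 2 (0.83 log units; beyond the scatter) went with the loss of a five-membered ring and the change to compound 3 restores one, the expected step of a 3.1-fold lower number from compound 2 to compound 3 (0.50 log units; beyond the scatter) is estimated as a modest fall, partly reversing it. Compound 3 is expected near 1500 nM, within a range from 500 nM to 5000 nM.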

Compound 3, half-maximal inhibitory concentration: 550 nM
Estimate against measurement, compound 3: 2.7-fold (0.44 log units) above; low and high end bracket the measured number.
By their numbers in this assay, from the lowest: compounds 3 and 1 (each within the scatter of the next); then compound 2.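

In this assay, restoring a five-membered ring on this carbonyl carbon undoes the whole loss that came with the open 1-aminobutyl chain (an 8.5-fold lower number from compound 2 to compound 3 (0.93 log units; beyond the scatter)). The ring also accepts a sulfur atom, since 1,3-thiazolidin-4-yl in place of pyrrolidin-2-yl leaves the number level (a 1.3-fold lower number from compound 1 to compound 3 (0.10 log units; within the scatter)). Nothing at hand explains either step. From the compounds shown here alone, it remains open whether a six-membered piperidine ring would serve as well as these five-membered rings. Going by these compounds, the effect of a carboxylic acid or a methyl group on the ring also remains open.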